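Cytotoxicity of three analogues and one new compound

The source may hold more compounds than are shown below. What is called first, only, known or untested is meant among the compounds shown, and "the series" means these compounds.

Compound 1, `CC(C)Cc1ccc2c(NCCCNCc3ccco3)ccnc2c1`, gives 16000 nM in an ADME assay on HepG2 cells (Homo sapiens) for cytotoxicity, read by luminescence, CellTiter-Glo and ATP content, with a stated time of 72 h; on this read-out lower numbers stand for an effect already at smaller amounts and higher numbers for an effect only at larger amounts of compound.
Compound 2, `FC(F)(F)c1ccc(-c2ccc3c(NCCCNCc4ccco4)ccnc3c2)cc1`, gives 3470 nM in this assay.
Compound 3, `c1coc(CNCCCNc2ccnc3cc(CC4CCCCC4)ccc23)c1`, gives 1700 nM in this assay.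

Compound 3 stands lowest of the three: a 9.4-fold lower number from compound 1 to compound 3 (0.97 log units; beyond the scatter) and a 2.0-fold lower number from compound 2 to compound 3 (0.31 log units; beyond the scatter), both beyond the scatter. Compound 4, `COc1cccc(Oc2ccc3c(NCCCNCc4ccco4)ccnc3c2)c1`, is not yet measured; it differs from compound 3 by 3-methoxyphenoxy in place of cyclohexylmethyl on an aromatic carbon. Going by the values given here, the steps that bear on this change are a 9.4-fold lower number from compound 1 to compound 3 (0.97 log units; beyond the scatter) and a 2.0-fold lower number from compound 2 to compound 3 (0.31 log units; beyond the scatter): in each, cyclohexylmethyl at this position gives the lower number, and compound 2, which also carries an aromatic group there, sits between. Compound 4 is therefore expected to move back toward the higher numbers, a step of a 3.5-fold higher number from compound 3 to compound 4 (0.55 log units; beyond the scatter), giving an estimate of 6000 nM with a range from 2500 nM to 15000 nM.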

Compound 4, half-maximal effective concentration: 15500 nM
For compound 4 the middle estimate is 2.6-fold (0.41 log units) below the measured one; the measured number lies above the stated range.
By their numbers in this assay, from the lowest: compound 3; then compound 2; then compounds 4 and 1 (each within the scatter of the next).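

In this assay the change from cyclohexylmethyl to 3-methoxyphenoxy gives a 9.1-fold higher number from compound 3 to compound 4 (0.96 log units; beyond the scatter) and the change from 4-(trifluoromethyl)phenyl to 3-methoxyphenoxy gives a 4.5-fold higher number from compound 2 to compound 4 (0.65 log units; beyond the scatter) at this aromatic carbon. Set against isobutyl, 3-methoxyphenoxy gives a 1.0-fold lower number from compound 1 to compound 4 (0.01 log units; within the scatter) and so shows no change, while compound 2 and compound 4, which both carry an aromatic ring here, stand apart beyond the scatter. Nothing given explains these differences. The compounds shown leave open how plain phenoxy would compare with 3-methoxyphenoxy. They also leave open where an amine or a carboxylic acid on this carbon would stand.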